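Bromine for Fluorine on the Indole of Compound 3

A few compounds are considered here, and "the series" means these few. Any claim that something is new, unique, unknown or untested is made for them only; others in the source may bear on it.

Compound 1, `CO[C@@H]1[C@H](N(C)c2ncc(-c3c[nH]c4ccc(Br)cc34)s2)C[C@H]2O[C@]1(C)n1c3ccccc3c3c4c(c5c6ccccc6n2c5c31)C(=O)NC4`: in a functional assay on HL-60 cells (Homo sapiens) for antiproliferative activity, read by CellTiter-Glo, with a stated time of 72 h (on this read-out higher numbers stand for weaker inhibition and lower numbers for stronger inhibition), compound 1 gives only the limit > 10000 nM.
Compound 2, `CO[C@@H]1[C@H](N(C)c2ncc(-c3c[nH]c4ccccc34)s2)C[C@H]2O[C@]1(C)n1c3ccccc3c3c4c(c5c6cc(Br)ccc6n2c5c31)C(=O)NC4`: in this assay compound 2 gives only the limit > 10000 nM.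
Compound 3, `CO[C@@H]1[C@H](N(C)c2ncc(-c3c[nH]c4ccc(F)cc34)s2)C[C@H]2O[C@]1(C)n1c3ccccc3c3c4c(c5c6cc(Br)ccc6n2c5c31)C(=O)NC4`: in this assay compound 3 gives only the limit > 10000 nM.

Compound 3 therefore stands at the limit of this assay, not at a number, and it shares that position with both other compounds, as shown by the limit of > 10000 nM in this assay, at which 3 of the 3 values shown sit. For the measured compounds named here, the one measured step that leads to it, a step that the two limits leave unreadable from compound 2 to compound 3, cannot be read because both ends are limits, so it gives no direction and no size.

Compound 4, `CO[C@@H]1[C@H](N(C)c2ncc(-c3c[nH]c4ccc(Br)cc34)s2)C[C@H]2O[C@]1(C)n1c3ccccc3c3c4c(c5c6cc(Br)ccc6n2c5c31)C(=O)NC4`, has not been measured. It differs from compound 3 by bromo in place of fluoro on an aromatic carbon. Compound 1 already carries this bromo on its indole and also sits at the limit; the remaining difference between compound 1 and compound 4 is the bromo on the core, which compound 2 and compound 3 carry, both also at the limit. With no readable step anywhere, no shift beyond the scatter is expected in this assay, and compound 4 is expected to remain at the limit. The estimated step that the limit leaves unreadable from compound 3 to compound 4 is thus expected to be nil. The estimate for compound 4 is 15000 nM, within 5000 nM to 50000 nM.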

Compound 4, half-maximal inhibitory concentration: > 10000 nM
Compound 4: no number, only a limit; the forecaster's own chance of this, stated with the estimate: 85%; the middle value does not contradict the limit.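

For the compounds shown here, compound 4 gives only a limit in this assay, and no step from compound 1, compound 2 or compound 3 to it can be read, because all four compounds sit at the same limit: the limit of > 10000 nM in this assay, at which 4 of the 4 values shown sit.

The compounds shown leave open whether exchanging hydrogen, fluoro and bromo changes the activity at all.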